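The compounds below may be only part of what the source reports. "The series", "measured", "known", "first", "only" and "open" are said of these compounds alone.

Working notes on the series, read in a functional assay on A549 cells (Homo sapiens) for cytotoxicity, read by MTT assay, with a stated time of 48 h; on this read-out lower numbers stand for stronger inhibition and higher numbers for weaker inhibition. Compound 1 (`COc1cc([C@@H]2C[C@@]2(CO)C(=O)Nc2ccccc2)cc(OC)c1OC`) gives 43200 nM. Compound 2 (`COc1cc([C@H]2C[C@@]2(CO)C(=O)Nc2ccccc2)cc(OC)c1OC`) is recorded at > 100000 nM, which is a limit of the assay and not a number, so its position is known from one side only.

Among the measured compounds shown here, the sole measured step, an at least 2.3-fold higher number from compound 1 to compound 2 (0.36 log units; beyond the scatter), comes with the fact that compounds 1 and 2 differ only in the configuration as drawn. Going by these compounds, its true size stays open because of the limit of > 100000 nM in this assay, at which 1 of the 2 values shown sits.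

Compound 3 (`COc1cc([C@H]2C[C@@]2(CO)C(=O)NCc2ccc(C)cc2)cc(OC)c1OC`) keeps the drawn configuration of compound 2 and carries 4-methylbenzyl in place of phenyl on an amide-type nitrogen.

For the measured compounds named here, no measured step changes the group on this nitrogen, so the step with an at least 2.3-fold higher number from compound 1 to compound 2 (0.36 log units; beyond the scatter) bears on the question only by placing the starting point of compound 2 in the weak region of this assay. With so little to go on, only a modest move towards a lower number is expected, and the result may again be a limit.

The expected step is an at least 1.4-fold lower number from compound 2 to compound 3 (0.15 log units; that floor lies within the scatter). For compound 3 the estimated value is 70000 nM, with an expected range of 25000 nM to 140000 nM.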

Compound 3, half-maximal inhibitory concentration: 63800 nM
For compound 3 the middle estimate is 1.1-fold (0.04 log units) above the measured one; the range from low to high includes it.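

In this assay, the place on the amide-type nitrogen is now shown to respond to a change of group: with 4-methylbenzyl there, compound 3 gives 63800 nM, a number within the reach of the assay. Compound 2, with phenyl at this place, is recorded at > 100000 nM, which is a limit of the assay and not a number. The change from anilino to (4-methylbenzyl)amino reads as an at least 1.5-fold lower number from compound 2 to compound 3 (0.19 log units; that floor lies within the scatter), so a real shift towards a lower number is possible but not established, and its true size stays open because of a limit: the limit of > 100000 nM in this assay, at which 1 of the 3 values shown sits.

The compounds shown do not tell whether a plain benzyl or a longer chain such as 2-phenylethyl on this nitrogen would read like 4-methylbenzyl, so the added carbon before the ring and the methyl on the ring cannot be separated. The group on this nitrogen has also been changed in only one drawn configuration, which leaves open whether 4-methylbenzyl would give a similar step in the configuration of compound 1.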